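Nitro-chlorobenzamide series: cytotoxicity on Raji cells

A few compounds are considered here, and "the series" means these few. Any claim that something is new, unique, unknown or untested is made for them only; others in the source may bear on it.

Three amides of one shared core have been run in an ADME assay on Raji cells (Homo sapiens) for cytotoxicity, with a stated time of 72 h; on this read-out lower numbers stand for an effect already at smaller amounts and higher numbers for an effect only at larger amounts of compound. Compound 1 `O=C(Nc1cc(-c2nc3ccccc3s2)ccc1F)c1cc([N+](=O)[O-])ccc1Cl` reaches only a limit of the assay, > 25000 nM. Compound 2 `O=C(Nc1ccc(-c2ccccc2)cc1)c1cc([N+](=O)[O-])ccc1Cl` likewise gives only a limit, > 27000 nM. Compound 3 `Cc1cc(NC(=O)c2cc([N+](=O)[O-])ccc2Cl)cc(-c2nc3ccccc3o2)c1O` also stops at a limit, > 25000 nM. So compound 2 stands where the other two stand: no number, only a limit, as the limit of > 25000 nM in this assay, at which 2 of the 3 values shown sit, and the limit of > 27000 nM in this assay, at which 1 of the 3 values shown sits, record. Among the compounds with values here, no step between measured compounds can be read from such limits. Compound 4 `O=C(Nc1ccc(Cl)cc1)c1cc([N+](=O)[O-])ccc1Cl` differs from compound 2 by chloro in place of phenyl on an aromatic carbon. The step from compound 2 to compound 4 is expected to be a number no higher from compound 2 to compound 4 (the limit leaves the size open) in this assay, that is nothing beyond the scatter, because compound 2 sits at > 27000 nM and the whole series shows no toxicity. Compound 4 is therefore estimated at 27000 nM in this assay, with a range from 10000 nM to 60000 nM, most likely reported again only as a limit.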

Compound 4, half-maximal effective concentration: > 27000 nM
Compound 4 gave a limit, no number (the forecaster's own chance of this, stated with the estimate: 85%); the middle value lies on the limit itself.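

Compound 2 and compound 4 both give only limits, and the step of chloro in place of phenyl on an aromatic carbon cannot be read. The compounds shown leave open what concentration, if any, gives a half-maximal effect in this assay.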